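Cyclobutyl carboxamide in place of the hydroxy cyclohexyl ring

This account rests on a few compounds, and the source may have more. Where it says the series, first, only, none or still open, it means among the compounds named here.

Compound 1 `CO[C@H]1CC[C@H](Nc2cc(NCc3cnccc3C(F)(F)F)ncc2C#N)CC1`: a limit, > 10000 nM
Compound 2 `CC1(C)C[C@@H](Nc2cc(NCc3cnccc3C(F)(F)F)ncc2C#N)CC[C@@H]1O`: 2400 nM

In an assay on isolated protein for inhibition of protein kinase C delta type (Homo sapiens), read by TR-FRET, with a stated time of 2 h (a higher number here means a weaker inhibitor, a lower number a stronger inhibitor), compound 1 gives only a limit, > 10000 nM, as noted under (the limit of > 10000 nM in this assay, at which 1 of the 2 values shown sits). In this assay, for the measured compounds named here, compound 2 gives 2400 nM, the only number among the measured compounds. Going by the values given here, the one measured step, an at least 4.1-fold lower number from compound 1 to compound 2 (0.61 log units; beyond the scatter), shows that exchanging the ring attached to the aromatic nitrogen moves the read-out at least modestly.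

Compound 3 `CC1(C)[C@@H](Nc2cc(NCc3cnccc3C(F)(F)F)ncc2C#N)C[C@H]1C(N)=O` is not yet measured. It differs from compound 2 by 3-carbamoyl-2,2-dimethylcyclobutyl in place of 4-hydroxy-3,3-dimethylcyclohexyl on a nitrogen on an aromatic ring. Among the compounds with values here, no measured step covers this change: the step from compound 1 to compound 2 kept a six-membered ring and altered only its substituents, whereas here the ring shrinks to four members and the hydroxyl gives way to a carboxamide. The estimate for compound 3 in this assay therefore rests on compound 2 alone, with wide uncertainty and no firm direction, though the change is expected to be at least as large as an at least 4.1-fold lower number from compound 1 to compound 2 (0.61 log units; beyond the scatter) in either sense. Compound 3 is expected at 3500 nM, within 700 nM to 15000 nM, an expected step of a 1.5-fold higher number from compound 2 to compound 3 (0.16 log units; within the scatter).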

Compound 3, half-maximal inhibitory concentration: 4500 nM
Beside the measured number, compound 3's estimate is 1.3-fold (0.11 log units) below it, and the stated range covers the measured number.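

In this assay, the change of ring gives a 1.9-fold higher number from compound 2 to compound 3 (0.27 log units; within the scatter), so at this place, on a nitrogen on an aromatic ring, the 3-carbamoyl-2,2-dimethylcyclobutyl and 4-hydroxy-3,3-dimethylcyclohexyl groups cannot be told apart, even though the ring shrinks from six members to four and a carboxamide replaces the hydroxyl. Set against the 4-methoxycyclohexyl group, the cyclobutyl group gives an at least 2.2-fold lower number from compound 1 to compound 3 (0.34 log units; beyond the scatter), which shows that a second, quite different ring also moves the read-out beyond the scatter in the same direction as the hydroxy dimethyl ring did. That step is only a bound, as compound 1 gives a limit and not a number: the limit of > 10000 nM in this assay, at which 1 of the 3 values shown sits.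

The compounds shown do not separate the contribution of the two ring methyl groups from that of the hydroxyl or carboxamide, as both groups that enter carry all of these features' counterparts and the 4-methoxycyclohexyl group carries neither. From the compounds shown here alone, how a plain 4-hydroxycyclohexyl group would read, or a dimethylcyclobutyl group bearing a carboxylic acid or an amine in place of the carboxamide, remains open.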